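Saturated or unsaturated acid chain at the shared aniline

The compounds below may be only part of what the source reports. "The series", "measured", "known", "first", "only" and "open" are said of these compounds alone.

Measured compounds:
- compound 1, `Cc1nc(-c2ccc(C(F)(F)F)cc2)sc1CNc1ccc(CCC(=O)O)cc1`, gives 108%
- compound 2, `O=C(O)/C=C/c1ccc(NCc2cccc(Oc3ccccc3)c2)cc1`, gives 76%

Both compounds were tested in a functional assay on CHO cells for agonist activity at Free fatty acid receptor 1 (Homo sapiens), read by a luciferase reporter; a lower number here means a smaller maximal response, a higher number a larger maximal response. Compound 1 stands highest of the two numbers, and the nearest neighbour, compound 2, lies lower by a gap that is beyond the usual scatter; since the two differ in more than one place, the gap alone does not tell which part of the structure matters.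

The unmeasured compound 3, `Cc1nc(-c2ccc(C(F)(F)F)cc2)sc1CNc1ccc(/C=C/C(=O)O)cc1`, keeps the whole core of compound 1 and changes only the acid side chain: 2-carboxyethenyl in place of 2-carboxyethyl on an aromatic carbon. Compound 2 shows that the 2-carboxyethenyl chain can sit in an active compound, while the remaining difference in the shared core leaves the effect of the chain alone open. The step from compound 1 to compound 3 in this assay is therefore expected to be small, possibly a slight decrease, and likely within the scatter, as a number 11 percentage points lower from compound 1 to compound 3 (beyond the scatter). Compound 3 is expected to give 97%, within a range from 75% to 115%.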

Compound 3, largest response reached (reported as percent of maximum), in percent of the reference or control that the assay uses: 95%
The estimate for compound 3 lay 2 percentage points above the measured number; measured number inside the range.
By their numbers in this assay, from the lowest: compound 2; then compound 3; then compound 1.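

Here the shared core stays fixed, so the acid chain can be judged on its own for the first time: in this assay, placing 2-carboxyethenyl in place of 2-carboxyethyl on the aromatic carbon gives a number 13 percentage points lower from compound 1 to compound 3 (beyond the scatter) and thus a modest loss of maximal response. The added double bond outside the aromatic rings therefore lowers the response on this core without removing it, as compound 3 still gives 95% in this assay here. Nothing measured on hand explains this step.

From the compounds shown here alone, it remains open whether a longer chain ending in a carboxylic acid, or a primary amide in place of the carboxylic acid, would be tolerated at this position. Going by these compounds, the size of this same chain change on the core of compound 2 also remains open.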